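Swapping isobutyl for 3-methoxyphenoxy: expected solubility shift

The compounds below may be only part of what the source reports. "The series", "measured", "known", "first", "only" and "open" are said of these compounds alone.

Measured compounds:
Compound 1, `CC(C)(C)c1ccc(Oc2ccc3c(NCCCNCc4ccco4)ccnc3c2)cc1`: 14500 nM
Compound 2, `Cc1cc(C)cc(Cc2ccc3c(NCCCNCc4ccco4)ccnc3c2)c1`: 4200 nM
Compound 3, `CC(C)Cc1ccc2c(NCCCNCc3ccco3)ccnc2c1`: 4200 nM

In a physicochemical assay for solubility, with a stated time of 18 h, at pH 7.4 (on this read-out lower numbers stand for lower solubility and higher numbers for higher solubility), compound 3 gives 4200 nM, level with compound 2 and together with it the lowest of the three numbers; compound 1 gives 14500 nM, a higher number that lies beyond the scatter. Among the measured compounds shown here, the one single-point step that has been measured, no change at the digits printed from compound 2 to compound 3 (within the scatter), shows that trading one carbon-based side group for another left this assay unchanged.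

Compound 4, `COc1cccc(Oc2ccc3c(NCCCNCc4ccco4)ccnc3c2)c1`, has not yet been measured. It differs from compound 3 as follows: 3-methoxyphenoxy in place of isobutyl on an aromatic carbon. For the measured compounds named here, no measured step covers this exact exchange. Going by the values given here, compound 1, which also carries a phenoxy group on the shared core, gives 14500 nM, the highest number so far, while compound 3 gives 4200 nM. On that basis compound 4 is expected to move upward, by a step of about a 3.3-fold higher number from compound 3 to compound 4 (0.52 log units; beyond the scatter), because compound 1 stands at 14500 nM. The estimate for compound 4 is 14000 nM, with a range from 4500 nM to 45000 nM.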

Compound 4, solubility: 14500 nM
The estimate for compound 4 lay 1.0-fold (0.02 log units) below the measured number, and the stated range covers the measured number.
By their numbers in this assay, from the lowest: compounds 2 and 3 (each within the scatter of the next); then compounds 1 and 4 (each within the scatter of the next).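

In this assay, among the compounds shown here, putting 3-methoxyphenoxy on this aromatic carbon gives a 3.5-fold higher number from compound 3 to compound 4 (0.54 log units; beyond the scatter) in place of isobutyl and a 3.5-fold higher number from compound 2 to compound 4 (0.54 log units; beyond the scatter) in place of 3,5-dimethylbenzyl , so both carbon-linked groups now sit on the lower side of a phenoxy group, with no compound here going against that pattern. Changing the ring on the oxygen, with 3-methoxyphenyl in place of 4-(tert-butyl)phenyl, gives no change at the digits printed from compound 1 to compound 4 (within the scatter) and so does not separate the two phenoxy compounds. No measurement here offers an explanation for the higher numbers of the phenoxy compounds.

The compounds shown leave open whether the oxygen link or the ring on it carries the step, which an unsubstituted phenoxy or a plain phenyl group could help to test. Where a primary amine, a carboxylic acid or a longer alkyl chain at this position would stand also remains open.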